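A Chain-Linked Acid Series Heading Toward a Chlorinated Analogue

A few compounds are considered here, and "the series" means these few. Any claim that something is new, unique, unknown or untested is made for them only; others in the source may bear on it.

Compound 1 `Cc1c(OCCCCOc2ccccc2C(=O)O)ccc(C(=O)CC2CCCC2)c1C` has "not determined" (no result reported) in an assay on HEK293 cells for positive allosteric modulation of metabotropic glutamate receptor 3 (Rattus norvegicus), read by thallium flux, with a stated time of 2.5 min (a higher number here means that more compound is needed for the effect, a lower number that less compound is needed), so no single number stands for it. Compound 3 `Cc1c(OCCCCOc2ccccc2C(=O)O)ccc(C(=O)CC2CCCC2)c1O` likewise shows "not determined" (no result reported) in this assay. Compound 2 `Cc1c(OCCCCOc2ccc(C(=O)O)cc2Cl)ccc(C(=O)CC2CCCC2)c1O` reaches only a limit in this assay, > 10000 nM, rather than a measured number; that is the limit of > 10000 nM in this assay, at which 1 of the 3 values shown sits. Compound 4 `Cc1c(OCCCCOc2ccc(C(=O)O)c(Cl)c2)ccc(C(=O)CC2CCCC2)c1C` differs from compound 1 in one place: 4-carboxy-3-chlorophenyl in place of 2-carboxyphenyl on an oxygen on a saturated carbon. No measured step between any two of these compounds exists, so the size of the change in this assay cannot be read from earlier pairs; the expectation is that compound 4 stays in the weak region where compound 2 sits, with no shift beyond the scatter. Compound 4 is expected to give 15000 nM in this assay, within 3000 nM to 60000 nM, quite possibly reported only as a limit.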

Compound 4, half-maximal effective concentration: > 10000 nM
Compound 4 gave a limit, no number; the forecaster's own chance of this, stated with the estimate: 70%; the middle value lies beyond the limit too.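

In this assay compound 4 gives > 10000 nM, a limit rather than a number. Among these compounds, compound 1 has no single number, so no step between compound 1 and compound 4 can be read. The compounds shown leave open what concentration, if any, produces the effect, and the values reach no further than this: the limit of > 10000 nM in this assay, at which 2 of the 4 values shown sit.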